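The source may report more compounds than this note shows. Statements on the series, on what has been measured and on what is new or still open speak of the compounds shown alone.

Among the compounds with values here, compound 2 `O=C(Nc1ccc(Cl)cc1)Nc1c(C(O)(C(F)(F)F)C(F)(F)F)ccc2ccccc12` carries, in an assay on LtK cells with ATP-sensitive inward rectifier potassium channel 11 (Homo sapiens) as the target (on this read-out higher numbers stand for an effect only at larger amounts of compound and lower numbers for an effect already at smaller amounts), the highest number of the two compounds measured so far: compound 2 gives 276 nM. Its nearest neighbour is compound 1 `O=C(CC1CCCC1)Nc1c(C(O)(C(F)(F)F)C(F)(F)F)ccc2ccccc12`, which in this assay gives 81 nM. Within the data shown here, the single measured step between them, a 3.4-fold higher number from compound 1 to compound 2 (0.53 log units; beyond the scatter), puts a nitrogen-linked aromatic group where a carbon-linked ring chain had been on the carbonyl carbon. Compound 3 `O=C(Nc1c(C(O)(C(F)(F)F)C(F)(F)F)ccc2ccccc12)c1ccccc1` has not yet been measured. It differs from compound 2 in one place: phenyl in place of (4-chlorophenyl)amino on a carbonyl carbon. Cut one bond further out, the change reads (4-chlorophenyl)carbamoyl to benzoyl, which brings the attachment to the carbonyl carbon back to a carbon-linked group, as in compound 1. Among the measured compounds shown here, the measured step of a 3.4-fold higher number from compound 1 to compound 2 (0.53 log units; beyond the scatter) bears on this only loosely, since the ring groups are not the same, but it is the one guide available and points to a modest move downward in this assay. Compound 3 is therefore expected to give 120 nM, within a range of 40 nM to 400 nM. This estimate amounts to a step of a 2.3-fold lower number from compound 2 to compound 3 (0.36 log units; beyond the scatter).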

Compound 3, half-maximal effective concentration: 44 nM
The estimate for compound 3 lay 2.7-fold (0.44 log units) above the measured number; measured number inside the range.
By their numbers in this assay, from the lowest: compounds 3 and 1 (each within the scatter of the next); then compound 2.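

In this assay, the new result shows that what matters on this carbonyl carbon is not simply the presence of an aromatic ring: the group that leaves and the group that enters each hold one six-membered aromatic ring of carbon only, yet swapping (4-chlorophenyl)amino for phenyl gives a 6.3-fold lower number from compound 2 to compound 3 (0.80 log units; beyond the scatter). The other new step, a 1.8-fold lower number from compound 1 to compound 3 (0.27 log units; within the scatter), lies within the scatter, so phenyl and cyclopentylmethyl cannot be told apart here, and among these three compounds the two with a carbon-linked group stand together, while compound 2, with its nitrogen-linked group, stands apart from both. Nothing available explains why these numbers differ in this way.

The step to compound 3 removes the linking nitrogen and the chlorine together, so the compounds shown cannot say which of the two accounts for the change. A phenylamino group or a 4-chlorophenyl group on the same carbonyl carbon would separate the two, each differing from compound 3 in only one of them.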